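Chloro on the phenyl ketone series: working notes

A few compounds are considered here, and "the series" means these few. Any claim that something is new, unique, unknown or untested is made for them only; others in the source may bear on it.

compound 1 (`CCN(CC)C(=S)SC(CC(=O)c1ccccc1)c1ccccc1`) gives 17000 nM
compound 2 (`CCN(CC)C(=S)SC(CC(=O)c1ccccc1)c1cccc([N+](=O)[O-])c1`) gives 9000 nM

Within the data shown here, in a functional assay on MCF7 cells (Homo sapiens) for cytotoxicity, read by MTT assay, with a stated time of 48 h (on this read-out higher numbers stand for weaker inhibition and lower numbers for stronger inhibition), compound 1 stands within the scatter of the only other measured compound, and the single step is a 1.9-fold lower number from compound 1 to compound 2 (0.28 log units; within the scatter) here. Compound 3 (`CCN(CC)C(=S)SC(CC(=O)c1ccc(Cl)cc1)c1ccccc1`) differs from compound 1 by chloro in place of hydrogen on an aromatic carbon (chloro in place of hydrogen on an aromatic carbon, phenyl to 4-chlorophenyl). Among the measured compounds shown here, only that one measured step bears on this change, and it places nitro, not chloro, on an aromatic carbon. No step beyond the scatter is therefore expected, only a slight drop in the number if any. The expected change is small (a 1.3-fold lower number from compound 1 to compound 3 (0.12 log units; within the scatter)) on this estimate. Compound 3 is estimated at 13000 nM (range 5500 nM to 30000 nM) in this assay for now.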

Compound 3, half-maximal inhibitory concentration: 40 nM
Compound 3: middle estimate off by 330-fold (2.51 log units), on the high side, outside the stated range (below it).
By their numbers in this assay, from the lowest: compound 3; then compounds 2 and 1 (each within the scatter of the next).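

In this assay chloro in place of hydrogen on an aromatic carbon, phenyl to 4-chlorophenyl, gives a 430-fold lower number from compound 1 to compound 3 (2.63 log units; beyond the scatter) in a single change. The earlier nitro step, on a different ring, was a 1.9-fold lower number from compound 1 to compound 2 (0.28 log units; within the scatter) and gave no sign that one added atom could move the number this far, so this position is highly sensitive to the change. Nothing measured here accounts for the size of this step.

As far as these compounds go, whether the step is specific to chloro remains open, since neither fluoro, methoxy nor an amine appears at this position. Also open, from the compounds shown here alone, is whether chloro on the other ring would give a similar step.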